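Acetophenone ether series: acid in place of tetrazole

This account rests on a few compounds, and the source may have more. Where it says the series, first, only, none or still open, it means among the compounds named here.

Measured so far:
compound 1 `CCCc1c(OCCCCOc2ccc(-c3nn[nH]n3)cc2)ccc(C(C)=O)c1O` — 348 nM
compound 2 `CC(=O)c1ccc(OCCCCOc2ccc(-c3nn[nH]n3)cc2)c(Br)c1O` — 878 nM

In an assay on isolated protein for binding affinity to metabotropic glutamate receptor 2 (Homo sapiens), read by GTPgammaS binding (a higher number here means that more compound is needed for the effect, a lower number that less compound is needed), compound 1 gives 348 nM, the lowest of the two numbers; compound 2 sits next to it with 878 nM, reached by a 2.5-fold higher number from compound 1 to compound 2 (0.40 log units; beyond the scatter). Compound 3 `CCCc1c(OCCCCOc2ccc(C(=O)O)cc2)ccc(C(C)=O)c1O` differs from compound 1 by carboxy in place of 2H-tetrazol-5-yl on an aromatic carbon. Among the compounds with values here, no measured step in this assay touches that part of the molecule; the bromo-for-propyl step gives no guide here. Pending a result, the step is expected to be a 2.0-fold higher number from compound 1 to compound 3 (0.30 log units; within the scatter), with a wide range. For compound 3 the estimate in this assay is 700 nM, expected between 200 nM and 3000 nM.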

Compound 3, half-maximal effective concentration: 1820 nM
Compound 3: middle estimate off by 2.6-fold (0.41 log units), on the low side; the range from low to high includes it.
By their numbers in this assay, from the lowest: compound 1; then compound 2; then compound 3.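

In this assay, carboxy in place of 2H-tetrazol-5-yl gives a 5.2-fold higher number from compound 1 to compound 3 (0.72 log units; beyond the scatter) at this place, para to a large group. Within the data shown here, the earlier step changed only the other end of the molecule, so this is the first sign that the potency of the series depends on the group held here, and that carboxy does not fully stand in for the tetrazole. No data at hand explain the step.

From the compounds shown here alone, it remains open whether the same step holds with bromo in place of propyl, as in compound 2. Also open, going by these compounds, is how a primary amide, a methyl ester or a sulfonamide would compare at this place.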